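Amide aryl swap on a shared core: propyl for dimethyl

The source may report more compounds than this note shows. Statements on the series, on what has been measured and on what is new or still open speak of the compounds shown alone.

Measured so far:
compound 1, `O=C(Nc1cccc(-c2oc3cc(-c4ccc(F)cc4)ccc3c(=O)c2O)c1)c1ccc(F)cc1F`, which in a functional assay on GTL 16 cells for antiproliferative activity against GTL 16 cell line (Homo sapiens), read by CCK-8 assay, with a stated time of 72 h (a higher number here means a weaker inhibitor, a lower number a stronger inhibitor), gives 9640 nM
compound 2, `Cc1cc(C)cc(C(=O)Nc2cccc(-c3oc4cc(-c5ccc(F)cc5)ccc4c(=O)c3O)c2)c1`, which in this assay gives 13500 nM

Compound 2 has the higher of the two numbers, but the step of a 1.4-fold higher number from compound 1 to compound 2 (0.15 log units; within the scatter) lies within the scatter, so the two compounds are not separated. Compound 3, `CCCc1ccc(C(=O)Nc2cccc(-c3oc4cc(-c5ccc(F)cc5)ccc4c(=O)c3O)c2)cc1`, differs from compound 2 by 4-propylphenyl in place of 3,5-dimethylphenyl on a carbonyl carbon. Among the measured compounds shown here, only that one measured step, a change of the same aryl group on the carbonyl carbon, bears on this swap, and it stayed within the scatter. No change beyond the scatter is therefore expected. The step expected is a 1.1-fold lower number from compound 2 to compound 3 (0.05 log units; within the scatter). Compound 3 is expected to give about 12000 nM, between 5000 nM and 30000 nM.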

Compound 3, half-maximal inhibitory concentration: 20400 nM
Estimate against measurement, compound 3: 1.7-fold (0.23 log units) below; the range from low to high includes it.
By their numbers in this assay, from the lowest: compounds 1, 2 and 3 (each within the scatter of the next, the first and the last beyond it).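

In this assay, 4-propylphenyl on the carbonyl carbon is not separated from 3,5-dimethylphenyl (a 1.5-fold higher number from compound 2 to compound 3 (0.18 log units; within the scatter)). Set against 2,4-difluorophenyl, however, it gives the only step at this position that passes the scatter, and a modest one (a 2.1-fold higher number from compound 1 to compound 3 (0.33 log units; beyond the scatter)). So the choice of aryl group here can shift the number, though only slightly among these three, and nothing available gives a reason for that shift. Still open, from the compounds shown here alone, is how this position would respond to an aryl group carrying an amine or a carboxylic acid, or to a butyl chain in place of the propyl.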